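The compounds below may be only part of what the source reports. "The series", "measured", "known", "first", "only" and "open" are said of these compounds alone.

Measured so far:
- compound 1 `CC(C)(C)c1cc(C(=O)Nc2cccc(CN)c2)n(Cc2ccccc2)n1`: 2.2
- compound 2 `NCc1csc(NC(=O)c2cc3ccccc3o2)n1`: 1.1

In a physicochemical assay for lipophilicity, read by HPLC, at pH 3.0 (on this read-out lower numbers stand for lower lipophilicity and higher numbers for higher lipophilicity), compound 1 gives 2.2, the higher of the two numbers. The nearest number belongs to compound 2, which in this assay gives 1.1, a gap beyond the scatter. Going by the values given here, no two measured compounds differ in a single place, so no measured step is available, and the difference between compound 1 and compound 2 shows only what its two values show.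

Compound 3 `CNCc1csc(NC(=O)c2cc(C(C)(C)C)nn2Cc2ccccc2)n1` is not yet measured in this assay. Against compound 1 the change is 4-((methylamino)methyl)-1,3-thiazol-2-yl in place of 3-(aminomethyl)phenyl on an amide-type nitrogen. Among the compounds with values here, compound 2 also carries a 1,3-thiazol-2-yl on its amide-type nitrogen, but on a different core, so it gives no direct step. The expected step is a number 0.40 log units lower from compound 1 to compound 3 (beyond the scatter), a lowering that may not clear the scatter. Compound 3 is estimated at 1.8, within 1.3 to 2.3.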

Compound 3, distribution coefficient: 2.6
Estimate against measurement, compound 3: 0.80 log units below; the whole stated range lies below it.
By their numbers in this assay, from the lowest: compound 2; then compound 1; then compound 3.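

In this assay, 4-((methylamino)methyl)-1,3-thiazol-2-yl in place of 3-(aminomethyl)phenyl on an amide-type nitrogen gives a number 0.40 log units higher from compound 1 to compound 3 (beyond the scatter). At this position, then, a five-membered aromatic ring with 2 hetero atoms and added hydrogen-bond acceptors can accompany a higher number than the six-membered ring of carbon only, provided the methyl on the amine comes with it. Going by these compounds alone, the single step carries both differences at once, and nothing on hand accounts for its direction.

On these data alone, how the step divides between the ring and that methyl remains open; 4-(aminomethyl)-1,3-thiazol-2-yl on the same amide-type nitrogen would separate the two. Also open, as far as these compounds go, is whether a dimethylamine or a longer chain between ring and amine would move the number further in the same direction.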